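Removing a single fluorine from a low-responding analogue

A few compounds are considered here, and "the series" means these few. Any claim that something is new, unique, unknown or untested is made for them only; others in the source may bear on it.

Of the compounds shown here, three have been measured in an assay on HEK293 cells for positive allosteric modulation of metabotropic glutamate receptor 2 (Rattus norvegicus), read by thallium flux, with a stated time of 2.5 min; a lower number here means a smaller maximal response, a higher number a larger maximal response. Compound 1, `Cc1c(OCCCCOc2ccc(C(=O)O)cc2)ccc(C(=O)CC2CCCC2)c1O`, reaches 82.6%. Compound 2, `Cc1c(OCCCCOc2ccc(C(=O)O)cc2F)ccc(C(=O)CC2CCCC2)c1O`, reaches 83.8%. Compound 3, `Cc1c(OCCCCOc2ccc(F)c(C(=O)O)c2)ccc(C(=O)CC2CCCC2)c1C`, built on a different core, reaches only 14.6%, the lowest of the three, far beyond the scatter from compounds 1 and 2.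

Compounds 2 and 1 differ in one place, (hydrogen in place of fluoro on an aromatic carbon). That change gave a number 1.2 percentage points lower from compound 2 to compound 1 (within the scatter), a step that stays within the scatter.

Compound 4, `Cc1c(OCCCCOc2cccc(C(=O)O)c2)ccc(C(=O)CC2CCCC2)c1C`, is not yet measured. It differs from compound 3 in one place, (hydrogen in place of fluoro on an aromatic carbon). The difference between the cores of compound 3 and compound 2 is not broken down here. The change from compound 3 to compound 4 is the same kind of change as that from compound 2 to compound 1, but not the same: in the first pair the position was ortho to a large group and meta to a carboxy group, whereas here it is ortho to a carboxy group and para to a large group.

The step from compound 3 to compound 4 is expected to be small, a number 3.4 percentage points higher from compound 3 to compound 4 (within the scatter), because the comparable step a number 1.2 percentage points lower from compound 2 to compound 1 (within the scatter) lay within the scatter. Compound 3 gives a low starting point at 14.6%, so compound 4 is expected to give about 18%, estimated between 5% and 40%.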

Compound 4, largest response reached (reported as percent of maximum), in percent of the reference or control that the assay uses: 22.4%
Compound 4: middle estimate off by 4.4 percentage points, on the low side; the measured number falls inside the stated range.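

In this assay, swapping the 3-carboxy-4-fluorophenyl group of compound 3 for the 3-carboxyphenyl group of compound 4 gives a number 7.8 percentage points higher from compound 3 to compound 4 (within the scatter), so on this core, too, the loss of the fluoro leaves the response within the normal spread of repeat measurements. Set beside the same swap on the core of compound 1, this step does not stand apart: the same change on two cores in this assay, a number 1.2 percentage points lower (within the scatter) from compound 2 to compound 1 and a number 7.8 percentage points higher (within the scatter) from compound 3 to compound 4, 9 percentage points apart, within the scatter of two such steps

Across these two pairs, then, the change carries from one core to the other as a step too small to read, even though the fluoro stands ortho to a carboxy group in compound 3 and elsewhere on the ring in compound 2, but with one pair per core this does not show that the fluoro makes no difference on other cores or at other places on the ring.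

From the compounds shown here alone, it remains open whether a chloro or methoxy group on the same aromatic carbon would also leave the response in place. The compounds shown also leave open which part of the difference between the two cores goes with the response, and whether a single swap on the core, such as a methyl group for a hydroxy group, would carry the same weight with and without the fluoro.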